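A few compounds are considered here, and "the series" means these few. Any claim that something is new, unique, unknown or untested is made for them only; others in the source may bear on it.

Compound 1, `Cc1cc(=O)n(-c2cccc(F)c2)nc1C(=O)Nc1ccc(Oc2ncnc3[nH]ccc23)c(F)c1`, is measured in a functional assay on PC-3 cells (Homo sapiens) for cytotoxicity, read by MTT assay, with a stated time of 72 h (a lower number here means a stronger inhibitor, a higher number a weaker inhibitor), where compound 1 gives 6680 nM. Among the two numbers recorded, this is the lowest, and the only neighbour is compound 2, `Cc1ccc(-n2nc(C(=O)Nc3ccc(Oc4ncnc5[nH]ccc45)c(F)c3)c(C)cc2=O)cc1`, which in this assay gives 20400 nM. Going by the values given here, the one measured step, a 3.1-fold higher number from compound 1 to compound 2 (0.48 log units; beyond the scatter), swaps the aromatic group carried on a ring nitrogen of the shared core. Compound 3, `Cc1cc(=O)n(-c2cccc(F)c2)nc1C(=O)Nc1ccc(Oc2ncnc3c2ccn3C)c(F)c1`, differs from compound 1 in another way: methyl in place of hydrogen on an aromatic nitrogen, the place being an aromatic nitrogen of a five-membered ring within a fused system of two rings. Among the compounds with values here, no measured step touches that position, so the recorded change of the aryl group does not bear on it directly and the expected size is uncertain. A modest rise in the number is nevertheless expected, estimated as a 2.2-fold higher number from compound 1 to compound 3 (0.35 log units; beyond the scatter). For compound 3 the estimated value in this assay is 15000 nM, with a range from 5000 nM to 45000 nM.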

Compound 3, half-maximal inhibitory concentration: 8990 nM
Compound 3: the middle estimate sits 1.7-fold (0.22 log units) above what was measured, within the range that was stated.
By their numbers in this assay, from the lowest: compounds 1 and 3 (each within the scatter of the next); then compound 2.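

In this assay, methyl in place of hydrogen on the aromatic nitrogen of the five-membered ring gives a 1.3-fold higher number from compound 1 to compound 3 (0.13 log units; within the scatter) and so leaves the two compounds indistinguishable. For this pair, then, the cell reading does not require a hydrogen on that nitrogen, and a single added carbon there registers less clearly than the aryl exchange, which gives a 3.1-fold higher number from compound 1 to compound 2 (0.48 log units; beyond the scatter) and lies beyond the scatter. Nothing shown here offers an explanation for this result.

On these data alone, a single methyl says little about larger groups, so it remains open how a longer chain such as propyl, or a chain ending in an amine or a carboxylic acid, would read on this nitrogen. As far as these compounds go, it is equally open whether methyl there would behave the same way alongside the 4-methylphenyl group of compound 2.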